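Removing the alkyne from a fused bicyclic antiproliferative scaffold

The source may hold more compounds than are shown below. What is called first, only, known or untested is meant among the compounds shown, and "the series" means these compounds.

Within the data shown here, compound 2 `CCCCCCC#Cc1c(CCCCCC)oc2nc(=O)n(Cc3cn(Cc4ccccc4)nn3)cc12` is the one member of this small set with a numerical reading: in a functional assay on HepG2 cells (Homo sapiens) for antiproliferative activity, read by MTT assay, with a stated time of 72 h (a lower number here means a stronger inhibitor, a higher number a weaker inhibitor), compound 2 gives 25800 nM. Compound 1 `CCCCCCc1cc2cn(Cc3cn(-c4ccccc4F)nn3)c(=O)nc2o1`, which carries a fluorophenyl rather than a benzyl on the triazole and no alkyne on the core, is reported only as a limit in this assay, with compound 1 at > 100000 nM. Of the two entries shown, one therefore sits at the limit of > 100000 nM in this assay, at which 1 of the 2 values shown sits, and the other is a plain number, so no measured step between them can be stated.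

Compound 3 `CCCCCCc1cc2cn(Cc3cn(Cc4ccccc4)nn3)c(=O)nc2o1` keeps the benzyl-triazole of compound 2 and differs from it in a single place: hydrogen in place of oct-1-yn-1-yl on an aromatic carbon. Compound 1 likewise lacks the oct-1-yn-1-yl group, and its reading in this assay is the limit just named. On that basis, a weakening step is expected a 2.7-fold higher number from compound 2 to compound 3 (0.43 log units; beyond the scatter), larger than the usual scatter, with a fair chance that only a limit is returned. Compound 3 is accordingly estimated at 70000 nM, between 20000 nM and 200000 nM.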

Compound 3, half-maximal inhibitory concentration: 68700 nM
The estimate for compound 3 lay 1.0-fold (0.01 log units) above the measured number, within the range that was stated.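

In this assay, the oct-1-yn-1-yl group on this aromatic carbon of the five-membered ring now has a measured step of its own: replacing it with hydrogen gives a 2.7-fold higher number from compound 2 to compound 3 (0.43 log units; beyond the scatter), a modest weakening, and compound 3 still returns a plain number rather than a limit. The second new comparison concerns the other end of the molecule, where benzyl in place of 2-fluorophenyl on an aromatic nitrogen gives an at least 1.4-fold lower number from compound 1 to compound 3 (0.16 log units; that floor lies within the scatter), so this change is not shown to do anything beyond the scatter. That step has only a floor, as compound 1 is recorded as a limit and not as a number: the limit of > 100000 nM in this assay, at which 1 of the 3 values shown sits.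

The compounds shown leave open whether the weakening follows from losing the triple bond or from losing the eight-carbon chain, which a propargyl alcohol, a shorter alkynyl chain or a saturated octyl chain on the same carbon could separate. They also leave open how a group such as an amine or a phenyl would read at this carbon, and how 2-fluorophenyl on the aromatic nitrogen would read with oct-1-yn-1-yl in place.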